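The source may report more compounds than this note shows. Statements on the series, on what has been measured and on what is new or still open speak of the compounds shown alone.

Of the compounds shown here, three built on one shared core have been measured in a functional assay on MCF7 cells (Homo sapiens) for inhibition, read by MTT assay, with a stated time of 72 h; on this read-out lower numbers stand for stronger inhibition and higher numbers for weaker inhibition. Compound 1, `Cn1ccc2c(Oc3ccc(NC(=O)c4cn(-c5ccc(Br)cc5F)c5ccccc5c4=O)cc3F)ccnc21`, gives 420 nM in this assay. Compound 2, `Cn1ccc2c(Oc3ccc(NC(=O)c4cn(-c5ccc(C(F)(F)F)cc5Cl)c5ccccc5c4=O)cc3F)ccnc21`, differs from compound 1 by 2-chloro-4-(trifluoromethyl)phenyl in place of 4-bromo-2-fluorophenyl on an aromatic nitrogen, and in this assay compound 2 gives 190 nM; this change made a 2.2-fold lower number from compound 1 to compound 2 (0.34 log units; beyond the scatter). Compound 3, `O=C(Nc1ccc(Oc2ccnc3[nH]ccc23)c(F)c1)c1cn(-c2ccc(Br)cc2F)c2ccccc2c1=O`, differs from compound 1 in the core, namely by hydrogen in place of methyl on an aromatic nitrogen; in this assay compound 3 gives 1390 nM, and the step is a 3.3-fold higher number from compound 1 to compound 3 (0.52 log units; beyond the scatter). Among the three measured compounds, compound 2 shows the lowest number and compound 3 the highest.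

Compound 4, `O=C(Nc1ccc(Oc2ccnc3[nH]ccc23)c(F)c1)c1cn(-c2ccc(C(F)(F)F)cc2Cl)c2ccccc2c1=O`, has not yet been measured. It carries the core of compound 3 and differs from compound 3 by 2-chloro-4-(trifluoromethyl)phenyl in place of 4-bromo-2-fluorophenyl on an aromatic nitrogen. For the measured compounds named here, this is the same change, at the same place, as the one from compound 1 to compound 2, which on the core of compound 1 gave a 2.2-fold lower number from compound 1 to compound 2 (0.34 log units; beyond the scatter). The only difference between the two settings is the core itself, as described above, and nothing here shows how that core change and the aryl change interact.

Going by the values given here, for compound 4 the expected step is a 2.1-fold lower number from compound 3 to compound 4 (0.33 log units; beyond the scatter), resting on the single earlier instance, a 2.2-fold lower number from compound 1 to compound 2 (0.34 log units; beyond the scatter). Compound 4 is therefore estimated at 650 nM in this assay, with a plausible range from 300 nM to 1400 nM.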

Compound 4, half-maximal inhibitory concentration: 1120 nM
Compound 4: middle estimate off by 1.7-fold (0.24 log units), on the low side; measured number inside the range.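

In this assay, 2-chloro-4-(trifluoromethyl)phenyl in place of 4-bromo-2-fluorophenyl on the core of compound 3 gave a 1.2-fold lower number from compound 3 to compound 4 (0.09 log units; within the scatter), so on this core the step cannot be told from the scatter, while on the core of compound 1 it lay beyond it, yet the two steps do not differ by more than such a pair would scatter: the same change on two cores in this assay, a 2.2-fold lower number (0.34 log units; beyond the scatter) from compound 1 to compound 2 and a 1.2-fold lower number (0.09 log units; within the scatter) from compound 3 to compound 4, 1.8-fold (0.25 log units) apart, within the scatter of two such steps. Read the other way, hydrogen in place of methyl on the aromatic nitrogen gave a 5.9-fold higher number from compound 2 to compound 4 (0.77 log units; beyond the scatter), and this step also agrees with its earlier instance: the same change on two cores in this assay, a 3.3-fold higher number (0.52 log units; beyond the scatter) from compound 1 to compound 3 and a 5.9-fold higher number (0.77 log units; beyond the scatter) from compound 2 to compound 4, 1.8-fold (0.25 log units) apart, within the scatter of two such steps. Within these four compounds, both changes therefore carry from one setting to the other without a detectable interaction, but with only two instances of each this does not establish that the aryl change has a real effect on the core of compound 3, nor that the two changes are independent beyond this set.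

The compounds shown leave open whether an aryl group bearing an amine or a carboxylic acid would behave alike on both cores. They also leave open whether an ethyl group or a longer chain in place of methyl on the aromatic nitrogen would keep the numbers seen with methyl.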